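The source may hold more compounds than are shown below. What is called first, only, known or untested is meant among the compounds shown, and "the series" means these compounds.

Measured so far in an ADME assay on L02 cells (Homo sapiens) for antiproliferative activity, read by MTT assay, with a stated time of 48 h; a higher number here means a weaker inhibitor, a lower number a stronger inhibitor:
- compound 1 `CCn1c(C(=O)N(CCC#N)CCC#N)ccc1C(CC)(CC)c1ccc(OCCC(O)(CC)CC)c(C)c1`: 37800 nM
- compound 2 `CCn1c(C(=O)Nc2ccc(OC(F)(F)F)cc2)ccc1C(CC)(CC)c1ccc(OCCC(O)(CC)CC)c(C)c1`: > 50000 nM (a limit)
- compound 3 `CCOc1ccc(NC(=O)c2ccc(C(CC)(CC)c3ccc(OCCC(O)(CC)CC)c(C)c3)n2CC)cc1`: > 50000 nM (a limit)

Compound 3 has no number, only the limit > 50000 nM. That is the limit of > 50000 nM in this assay, at which 2 of the 3 values shown sit.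

Compound 4 `CCOC(=O)CN(C)C(=O)c1ccc(C(CC)(CC)c2ccc(OCCC(O)(CC)CC)c(C)c2)n1CC` is still unmeasured. Among the measured compounds shown here, the change is ((ethoxycarbonyl)methyl)(methyl)amino in place of (4-ethoxyphenyl)amino on a carbonyl carbon: the six-membered aromatic ring leaves, and the entering group, like the one in compound 1, has no ring.

For the measured compounds named here, two measured steps bear on this, an at least 1.3-fold higher number from compound 1 to compound 3 (0.12 log units; that floor lies within the scatter) and an at least 1.3-fold higher number from compound 1 to compound 2 (0.12 log units; that floor lies within the scatter). Both are only floors, so neither shows a real size. The step that the two limits leave unreadable from compound 2 to compound 3 adds nothing.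

Going by the values given here, the ringless group of compound 1, at 37800 nM, gives the only number to lean on. In this assay a small move toward a lower number is therefore expected, possibly none beyond the scatter. The expected step is an at least 1.2-fold lower number from compound 3 to compound 4 (0.09 log units; that floor lies within the scatter).

For compound 4 the estimate is 40000 nM, with an expected range of 20000 nM to 50000 nM.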

Compound 4, half-maximal inhibitory concentration: 1990 nM
The estimate for compound 4 lay 20-fold (1.30 log units) above the measured number; the whole stated range lies above it.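

In this assay the group on the carbonyl carbon can move the number far beyond the scatter: an at least 25-fold lower number from compound 3 to compound 4 (1.40 log units; beyond the scatter) and an at least 25-fold lower number from compound 2 to compound 4 (1.40 log units; beyond the scatter) both follow from ((ethoxycarbonyl)methyl)(methyl)amino entering in place of an anilide-type group. Losing the aromatic ring does not account for the whole change, since a 19-fold lower number from compound 1 to compound 4 (1.28 log units; beyond the scatter) separates two groups that both have no ring, on the same carbonyl carbon. Two of these steps are floors and not full sizes, as compound 2 and compound 3 each stand only at a limit: the limit of > 50000 nM in this assay, at which 2 of the 4 values shown sit.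

Open, on these data alone, is which part of the entering group carries the step, and a carboxylic acid in place of the ethyl ester would test that. A longer chain in place of the methylene, or an ethyl in place of the methyl on the amide nitrogen, would show how narrowly this group is defined.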